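Three Compounds, One Swap: Expecting Little Change

The source may hold more compounds than are shown below. What is called first, only, known or untested is meant among the compounds shown, and "the series" means these compounds.

compound 1 `Nc1ccc2oc(-c3ccccc3F)cc(=O)c2c1` gives 283000 nM
compound 2 `Nc1ccc2oc(-c3ccc(F)cc3)cc(=O)c2c1` gives 264000 nM
compound 3 `COc1ccccc1-c1oc2ccc(NC(C)=O)cc2c(=O)c1O` gives 385000 nM

All three numbers come from an ADME assay on MT4 cells (Homo sapiens) for cytotoxicity, read by MTT assay, with a stated time of 4 days; on this read-out lower numbers stand for higher toxicity in this test and higher numbers for lower toxicity in this test. They lie within the usual scatter of repeated measurements of one another, so compound 3, at 385000 nM, cannot be told apart from compound 1 or compound 2.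

The next compound to be tested is compound 4 `CC(=O)Nc1ccc2oc(-c3ccc(F)cc3)c(O)c(=O)c2c1`. It keeps the rest of compound 3 but carries 4-fluorophenyl in place of 2-methoxyphenyl on an aromatic carbon, next to the ring oxygen and ortho to a hydroxy group. The counted difference is 4-fluorophenyl in place of 2-methoxyphenyl on an aromatic carbon.

Going by the values given here, no two measured compounds differ in one place only, so no measured step shows directly what such a swap does. Among the compounds with values here, the nearest evidence is compound 2, which also carries 4-fluorophenyl and gives 264000 nM, a number within the scatter of the one for compound 3. Nothing in these few values points to a large move in this assay, in either direction. The expected change is a 1.3-fold lower number from compound 3 to compound 4 (0.11 log units; within the scatter), which would be no step beyond the scatter. For compound 4 the estimated value is 300000 nM, with an expected range from 170000 nM to 500000 nM.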

Compound 4, half-maximal cytotoxic concentration: 34100 nM
The estimate for compound 4 lay 8.8-fold (0.94 log units) above the measured number, outside the stated range (below it).
By their numbers in this assay, from the lowest: compound 4; then compounds 2, 1 and 3 (each within the scatter of the next).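

In this assay, putting 4-fluorophenyl in place of 2-methoxyphenyl on the aromatic carbon next to the ring oxygen and ortho to a hydroxy group gives an 11-fold lower number from compound 3 to compound 4 (1.05 log units; beyond the scatter), a large step well beyond the usual scatter. Going by these compounds alone, the earlier numbers all lay close together and included no pair differing in one place, so they gave no sign that this position could matter; this single exchange shows that the group held here can strongly shift the toxicity seen in this test, with compound 4 the more toxic of this pair. No measurement shown here explains why this one exchange has so large an effect.

The exchange alters both the group carried on the phenyl ring and where it sits on that ring, so the step cannot yet be assigned to the fluorine, to the loss of the methoxy group, or to either group's place. A 4-methoxyphenyl, a 4-chlorophenyl or a plain phenyl at this same position, with the rest of compound 4 kept, would help separate these possibilities and show how far the effect extends.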